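Opening the Ring on the Sulfur Substituent

This account rests on a few compounds, and the source may have more. Where it says the series, first, only, none or still open, it means among the compounds named here.

Three analogues share one core and differ only in the group on the sulfur. Compound 1 `CCC(O)CSc1nc(NCc2ccc(-c3ccccn3)cc2)c2[nH]nc(C(C)C)c2n1` carries 2-hydroxybutyl and in a functional assay on HT cells (Homo sapiens) for antiproliferative activity, read by fluorescence, with a stated time of 72 h (a lower number here means a stronger inhibitor of growth, a higher number a weaker inhibitor of growth), compound 1 gives 273 nM. Compound 2 `CC(C)c1n[nH]c2c(NCc3ccc(-c4ccccn4)cc3)nc(SCC(O)CN3CCNCC3)nc12` carries 2-hydroxy-3-(piperazin-1-yl)propyl, and in this assay compound 2 gives 332 nM. Compound 3 `CC(C)c1n[nH]c2c(NCc3ccc(-c4ccccn4)cc3)nc(SC3CCCC3O)nc12` carries 2-hydroxycyclopentyl, and in this assay compound 3 gives 567 nM, the highest of the three numbers: the step of a 2.1-fold higher number from compound 1 to compound 3 (0.32 log units; beyond the scatter) is modest but beyond the scatter, whereas a 1.7-fold higher number from compound 2 to compound 3 (0.23 log units; within the scatter) and a 1.2-fold higher number from compound 1 to compound 2 (0.08 log units; within the scatter) lie within it. Compound 4 `CCC(CO)Sc1nc(NCc2ccc(-c3ccccn3)cc2)c2[nH]nc(C(C)C)c2n1` is the next step: 1-(hydroxymethyl)propyl in place of 2-hydroxycyclopentyl on a sulfur. The step from compound 1 to compound 3 bears most directly on this change, since it too exchanged 2-hydroxybutyl on the sulfur for the five-membered ring; compound 4 returns to a chain of four carbons with one oxygen, now branched. A move back toward the number of compound 1 is therefore expected, a downward step of a 1.6-fold lower number from compound 3 to compound 4 (0.21 log units; within the scatter) that stays near the scatter. Compound 4 is expected to give 350 nM in this assay, with a range from 170 nM to 720 nM.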

Compound 4, concentration for 50% growth inhibition: 255 nM
Compound 4: middle estimate off by 1.4-fold (0.14 log units), on the high side; measured number inside the range.
By their numbers in this assay, from the lowest: compounds 4, 1, 2 and 3 (each within the scatter of the next, the first and the last beyond it).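

Among these compounds, opening the ring gives the clearest result at this position on the sulfur: 1-(hydroxymethyl)propyl in place of 2-hydroxycyclopentyl gives a 2.2-fold lower number from compound 3 to compound 4 (0.35 log units; beyond the scatter) in this assay, a modest step beyond the scatter. The open chains cannot be told apart, since the branched chain and 2-hydroxybutyl show a 1.1-fold lower number from compound 1 to compound 4 (0.03 log units; within the scatter) and the branched chain and 2-hydroxy-3-(piperazin-1-yl)propyl show a 1.3-fold lower number from compound 2 to compound 4 (0.11 log units; within the scatter) and both steps lie within the scatter. Nothing available here explains why the ring and the branched chain differ.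

The compounds shown leave open whether a carboxylic acid in place of the hydroxyl, or a simple amine on the chain, would stay in the same range. They also leave open how a longer chain or a six-membered carbocycle bearing a hydroxyl would behave on the sulfur.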